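Replacing naphthalenyl with dimethoxyphenyl: expected effect on cell viability

This account rests on a few compounds, and the source may have more. Where it says the series, first, only, none or still open, it means among the compounds named here.

Of the compounds shown here, three have been tested in an ADME assay on Vero cells (Chlorocebus sabaeus) for cytotoxicity, read by MTT assay, tested at 50 uM; a lower number here means a stronger effect, a higher number a weaker effect of the compound at the concentration tested. Compound 1 `CSc1ccc(C(=O)/C(=C/c2cccnc2)c2ccc(Cl)c(Cl)c2)cc1` gives 89.6%. Compound 2 `CCOC(=O)C(C(=O)c1ccc(OC)cc1)C(NC(C)=O)c1ccc(C(C)C)cc1`, which shares its core with the remaining compounds, gives 96.5%. Compound 3 `CCOC(=O)C(C(=O)c1ccc(OC)cc1)C(NC(C)=O)c1cccc2ccccc12` gives 98.7%. On paper the number of compound 3 is the largest of the three, but its gap to compound 2 and its gap to compound 1 both lie within the scatter, so the three cannot be ordered with confidence; all point to weak cytotoxicity at the concentration tested.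

Compound 4 `CCOC(=O)C(C(=O)c1ccc(OC)cc1)C(NC(C)=O)c1ccc(OC)c(OC)c1` has not yet been measured. It differs from compound 3 in one place: 3,4-dimethoxyphenyl in place of naphthalen-1-yl on a saturated chain carbon bound to an amide-type nitrogen and a saturated chain carbon.

Among the measured compounds shown here, the only measured step at that same place is the one from compound 2 to compound 3, where the aryl group on the saturated chain carbon was exchanged and the number moved by a number 2.2 percentage points higher from compound 2 to compound 3 (within the scatter). For the measured compounds named here, that step stayed within the scatter, so the single comparable precedent gives no reason to expect a move beyond the scatter for another aryl exchange at that position. The expected step of a number 2.7 percentage points lower from compound 3 to compound 4 (within the scatter) is therefore small, with no direction beyond the scatter.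

Compound 4 is expected to give about 96% in this assay, with a likely range from 86% to 100%.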

Compound 4, a percentage reported as activity, at one concentration (the size of the read-out at that concentration, not a potency): 96.7%
Compound 4: the middle estimate sits 0.7 percentage points below what was measured; the range from low to high includes it.
By their numbers in this assay, from the lowest: compounds 1, 2, 4 and 3 (each within the scatter of the next).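

Among the compounds shown here, at this position, on a saturated chain carbon bound to an amide-type nitrogen and a saturated chain carbon, the earlier compounds carried only aryl groups built from carbon, whereas compound 4 brings 3,4-dimethoxyphenyl, whose oxygen atoms add hydrogen-bond acceptors and which has one aromatic ring where naphthalen-1-yl has two. In this assay the exchange of naphthalen-1-yl is a number 2 percentage points lower from compound 3 to compound 4 (within the scatter) and the exchange of 4-isopropylphenyl is a number 0.2 percentage points higher from compound 2 to compound 4 (within the scatter), so at this single concentration the read-out does not separate these three aryl groups, even though they differ in ring count and in oxygen content. No measurement at hand offers an explanation for this result.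

All three groups compared here are aromatic rings without charge, so a piperidine or a carboxylic acid on the ring, or an open butyl chain in place of the ring, could still behave differently at this position. The ethyl ester and the 4-methoxybenzoyl part stay the same in compound 2, compound 3 and compound 4, so these compounds say nothing about changes at those places.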